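Ester to Methoxy Where Both Parents Hit the Limit

This account rests on a few compounds, and the source may have more. Where it says the series, first, only, none or still open, it means among the compounds named here.

Compound 2, `CCn1c(CNc2ccccc2)nnc1SCC(=O)Nc1ccc(C(=O)OC(C)(C)C)cc1`, is tested in an assay on isolated protein for inhibition of long-chain fatty acid transport protein 1 (Mus musculus); on this read-out higher numbers stand for weaker inhibition and lower numbers for stronger inhibition. There compound 2 reaches only the assay limit of > 10000 nM. Its neighbour compound 1, `CCn1c(CNc2ccccc2)nnc1SCC(=O)Nc1ccc(Cl)cc1`, likewise gives only the limit > 10000 nM. The step that the two limits leave unreadable from compound 1 to compound 2 therefore cannot be read, since the limit of > 10000 nM in this assay, at which 2 of the 2 values shown sit, hides any difference. Compound 3, `CCn1c(CNc2ccccc2)nnc1SCC(=O)Nc1ccc(OC)cc1`, differs from compound 2 by methoxy in place of tert-butoxycarbonyl on an aromatic carbon. Among the compounds with values here, no measured step offers a readable size, so no change beyond the scatter is expected, and compound 3 is expected to sit at 15000 nM within a range from 4000 nM to 60000 nM, which means an expected step that the limit leaves unreadable from compound 2 to compound 3.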

Compound 3, half-maximal inhibitory concentration: > 10000 nM
Compound 3 ended at the assay's limit; the forecaster's own chance of this, stated with the estimate: 80%; the middle value does not contradict the limit.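

No step among compound 1, compound 2 and compound 3 can be read in this assay, since each gives only a limit: the limit of > 10000 nM in this assay, at which 3 of the 3 values shown sit.

The compounds shown leave open how strongly any of the three inhibits, and whether changing this group on the aromatic ring can give a readable value.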